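This account rests on a few compounds, and the source may have more. Where it says the series, first, only, none or still open, it means among the compounds named here.

Measured so far in a functional assay on HL-60 cells (Homo sapiens) for cytotoxicity, read by MTT assay, with a stated time of 72 h; on this read-out lower numbers stand for stronger inhibition and higher numbers for weaker inhibition:
- compound 1 `CC(C)(C)c1nc2ccccc2n1C(=O)c1cccc2ccccc12`: 130 nM
- compound 2 `COc1ccc(C(=O)n2c(C(C)C)nc3ccccc32)cc1`: 630 nM
- compound 3 `COc1ccc(C(=O)n2c(C3CCCCC3)nc3ccccc32)cc1`: 85 nM

In this assay, compound 3 gives 85 nM and sits at the low end of this small set. Compound 1 lies within the scatter of it, while compound 2 lies clearly higher, beyond the scatter.

The next compound is compound 4 `COc1ccc(C(=O)n2c(-c3ccc(OC)cc3)nc3ccccc32)cc1`, which has 4-methoxyphenyl in place of cyclohexyl on an aromatic carbon. For the measured compounds named here, only one measured step changes a group on this aromatic carbon with the rest of the structure held: a 7.4-fold lower number from compound 2 to compound 3 (0.87 log units; beyond the scatter). That step is modest and beyond the scatter, but it involves no aromatic group, so it gives only a weak guide to the new change. Compound 1 differs from compound 3 in more than one place and adds little here. Going by the values given here, no measured compound carries an aromatic group on this carbon, so the direction is uncertain. A modest move to a higher number is the working expectation, and a result within the scatter would not be surprising.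

The expected change is a 2.0-fold higher number from compound 3 to compound 4 (0.30 log units; within the scatter).

Compound 4 is estimated at 170 nM, with an expected range of 35 nM to 800 nM.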

Compound 4, half-maximal inhibitory concentration: 175 nM
Estimate against measurement, compound 4: 1.0-fold (0.01 log units) below; measured number inside the range.
By their numbers in this assay, from the lowest: compounds 3, 1 and 4 (each within the scatter of the next, the first and the last beyond it); then compound 2.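

In this assay an aromatic ring on this aromatic carbon between two ring nitrogen atoms keeps most of the activity seen with cyclohexyl, with a 2.1-fold higher number from compound 3 to compound 4 (0.31 log units; beyond the scatter) as a modest cost. The same group still improves on isopropyl, with a 3.6-fold lower number from compound 2 to compound 4 (0.56 log units; beyond the scatter) as the step, so the three groups at this position now run from cyclohexyl at the lowest number through 4-methoxyphenyl to isopropyl at the highest, each step beyond the scatter. Nothing available explains this order.

On these data alone, whether the methoxy on the incoming ring matters remains open, since these compounds offer no comparison with plain phenyl or with a phenyl ring bearing an amine. Also open, as far as these compounds go, is whether a saturated ring larger than cyclohexyl, such as cycloheptyl, would lower the number further.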